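The source may hold more compounds than are shown below. What is called first, only, known or untested is meant among the compounds shown, and "the series" means these compounds.

Measured in a functional assay on Jurkat cells (Homo sapiens) for cytotoxicity, with a stated time of 72 h; on this read-out higher numbers stand for an effect only at larger amounts of compound and lower numbers for an effect already at smaller amounts (all three readings are limits):
Compound 1 `C=C[C@@](C)(/C=C/c1ccc(O)c(/C=C/C(=O)OCc2ccccc2)c1)CCC=C(C)C` gives > 49000 nM as a limit.
Compound 2 `C=C[C@@](C)(/C=C/c1ccc(O)c(/C=C/C(=O)O)c1)CCC=C(C)C` gives > 49000 nM as a limit.
Compound 3 `C=C[C@@](C)(/C=C/c1ccc(O)c(/C=C/c2ccc(Cl)cc2)c1)CCC=C(C)C` gives > 49000 nM as a limit.

Compound 3 thus has no number of its own, and the series as a whole stands at the limit of > 49000 nM in this assay, at which 3 of the 3 values shown sit, on the evidence so far. Compound 4 `C=C[C@@](C)(/C=C/c1ccc(O)c(/C=C/c2ccc(Cl)c(Cl)c2)c1)CCC=C(C)C` differs from compound 3 by a single change chloro in place of hydrogen on an aromatic carbon in which chloro takes the place of hydrogen on an aromatic carbon, turning 4-chlorophenyl to 3,4-dichlorophenyl.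

The nearest measured changes are a step that the two limits leave unreadable from compound 1 to compound 2 together with a step that the two limits leave unreadable from compound 1 to compound 3 and a step that the two limits leave unreadable from compound 2 to compound 3 and none of them has a readable size. None of them adds a substituent to the aromatic ring of compound 3 either. They give no direction for this assay and another limit is the likeliest outcome. The expected change is a step that the limit leaves unreadable from compound 3 to compound 4 with no direction expected beyond the scatter. For compound 4 the estimated value is 50000 nM with an expected range from 20000 nM to 100000 nM as the working estimate.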

Compound 4, half-maximal effective concentration: > 49000 nM
Compound 4 was reported as a limit; the forecaster's own chance of this, stated with the estimate: 75%; the middle value is on the limit's open side.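

Among the compounds shown here, no step from compound 1, compound 2 or compound 3 to compound 4 can be read, and the series remains at a single reading: the limit of > 49000 nM in this assay, at which 4 of the 4 values shown sit.

The compounds shown leave open whether in this assay any change on the shared core yields a value rather than a limit.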